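Swapping the aryl group on the triazole of a weak cytotoxic acid

The compounds below may be only part of what the source reports. "The series", "measured", "known", "first", "only" and "open" are said of these compounds alone.

The study concerns a set of cinnamic acids built on a shared core, two of which carry differing aryl groups on the triazole nitrogen. Compound 1 `COc1ccc(/C=C\C(=O)O)c(OCc2cn(-c3ccc(NC(=O)c4ccccc4)cc3)nn2)c1CC=C(C)C` bears a benzamido-substituted phenyl ring there; in a functional assay on PC-3 cells (Homo sapiens) for cytotoxicity, read by MTT assay, with a stated time of 24 h (a higher number here means a weaker inhibitor, a lower number a stronger inhibitor), compound 1 gives "not determined" (no result reported), so no number can be attached to it. Among the measured compounds shown here, compound 2 `COc1ccc(/C=C\C(=O)O)c(OCc2cn(-c3ccccc3F)nn2)c1CC=C(C)C` carries a 2-fluorophenyl ring at that position, and in this assay compound 2 gives 24200 nM, the only value available, which places it as a weak inhibitor.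

Compound 3 `COc1ccc(/C=C\C(=O)O)c(OCc2cn(-c3cccc(C#N)c3)nn2)c1CC=C(C)C` is the next variation: 3-cyanophenyl in place of 2-fluorophenyl on an aromatic nitrogen. For the measured compounds named here, no pair of measured compounds shares this change, so the size of the step has to be guessed rather than read from data. With nothing else to go on, the change is expected to move the potency little, if at all, beyond the usual scatter: the step of a 1.1-fold lower number from compound 2 to compound 3 (0.04 log units; within the scatter) is the expectation. Compound 3 is therefore estimated at 22000 nM in this assay, with a plausible range from 8000 nM to 60000 nM.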

Compound 3, half-maximal inhibitory concentration: 45500 nM
For compound 3 the middle estimate is 2.1-fold (0.32 log units) below the measured one, within the range that was stated.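

In this assay, exchanging 2-fluorophenyl for 3-cyanophenyl on the aromatic nitrogen amounts to a 1.9-fold higher number from compound 2 to compound 3 (0.27 log units; within the scatter), so this first readable pair shows no real separation between the two aryl groups at this position. The position therefore accepts a nitrile-bearing ring, with its added hydrogen-bond acceptor, without a change that can be told apart from the usual variation between repeats, and both compounds stay in the same weak range of the assay. Nothing available explains why these two aryl groups read alike.

The pair changes both the substituent and its place on the ring in a single step, so it cannot show what either change does alone, and compound 1 gives "not determined" (no result reported), which leaves the benzamido-substituted phenyl ring without a number to compare. On these data alone, whether a plain phenyl ring, or a phenyl ring carrying an amine or a carboxylic acid, would move the value on this aromatic nitrogen remains open.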